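Pyrrolidine amide series: human microsomal clearance, aryl to cyclopropyl

A few compounds are considered here, and "the series" means these few. Any claim that something is new, unique, unknown or untested is made for them only; others in the source may bear on it.

Measured compounds in an in vitro ADME assay on microsomes from liver (Homo sapiens) for pharmacokinetics, read by LC-MS, with a stated time of 10 min, tested at 1 uM; a higher number here means faster removal of the compound, a lower number slower removal:
- compound 1 `COc1cccc(NC(=O)[C@H]2CN(C)C[C@@H]2c2ccc(/C=C/C(=O)Nc3ccccc3N)cc2)c1`: 14 mL/min/kg
- compound 2 `CN1C[C@H](C(=O)Nc2ccccc2F)[C@@H](c2ccc(/C=C/C(=O)Nc3ccccc3N)cc2)C1`: 10 mL/min/kg
- compound 3 `CN1C[C@H](C(=O)Nc2ccc(F)c(Br)c2)[C@@H](c2ccc(/C=C/C(=O)Nc3ccccc3N)cc2)C1`: 15 mL/min/kg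

Compound 2 gives the lowest of the three numbers in this assay, but its separation from compound 1 (a 1.4-fold lower number from compound 1 to compound 2 (0.15 log units; within the scatter)) and from compound 3 (a 1.5-fold higher number from compound 2 to compound 3 (0.18 log units; within the scatter)) is within the scatter, so the three measured compounds are not distinguished. The step from compound 1 to compound 3 (a 1.1-fold higher number from compound 1 to compound 3 (0.03 log units; within the scatter)) is likewise within the scatter.

Compound 4 `CN1C[C@H](C(=O)NC2CC2)[C@@H](c2ccc(/C=C/C(=O)Nc3ccccc3N)cc2)C1` is not yet measured. It differs from compound 2 as follows: cyclopropyl in place of 2-fluorophenyl on an amide-type nitrogen. Within the data shown here, none of the measured steps exchanges the aromatic amide substituent for a non-aromatic ring, so they bear on this step only indirectly: each swap on the amide-type nitrogen so far has left this assay unchanged beyond the scatter. On that basis no step beyond the scatter is expected, and the step from compound 2 to compound 4 is estimated as a 1.2-fold higher number from compound 2 to compound 4 (0.08 log units; within the scatter). Compound 4 is expected to give 12 mL/min/kg, with a range from 6 mL/min/kg to 24 mL/min/kg.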

Compound 4, clearance: 10 mL/min/kg
Beside the measured number, compound 4's estimate is 1.2-fold (0.08 log units) above it; measured number inside the range.
By their numbers in this assay, from the lowest: compounds 2, 4, 1 and 3 (each within the scatter of the next).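

In this assay, the amide-type nitrogen now carries a non-aromatic ring among the measured compounds, and cyclopropyl in place of 2-fluorophenyl gives (no change at the digits printed from compound 2 to compound 4 (within the scatter)). Among these compounds, the exchange for the other two aromatic groups also stays within the scatter (a 1.5-fold lower number from compound 3 to compound 4 (0.18 log units; within the scatter); a 1.4-fold lower number from compound 1 to compound 4 (0.15 log units; within the scatter)), so across these four compounds neither an aromatic ring at this place nor 7 heavy atoms rather than 3 separates the numbers, and no compound goes against this. No measurement at hand gives a reason for this result.

Open, going by these compounds, is whether this insensitivity extends to an open-chain group such as isopropyl, or to a substituent carrying an amine or a carboxylic acid, on the amide-type nitrogen. Also open, on these data alone, is whether the same exchange reads alike with another part of the shared core altered.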